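A few compounds are considered here, and "the series" means these few. Any claim that something is new, unique, unknown or untested is made for them only; others in the source may bear on it.

Among the measured compounds shown here, in an ADME assay on MT4 cells (Homo sapiens) for cytotoxicity, read by MTT assay (on this read-out lower numbers stand for higher toxicity in this test and higher numbers for lower toxicity in this test), compound 1 `CC(=O)c1ccc(NC(=O)CSc2nncnc2-c2ccccc2Cl)c(Br)c1` gives 34000 nM, the lower of the two numbers so far, while compound 2 `CC(=O)c1ccc(NC(=O)CSc2nncnc2-c2cccc3ccccc23)c(Br)c1` gives 133000 nM. Compound 3 `CCOC(=O)c1ccc(NC(=O)CSc2nncnc2-c2ccccc2Cl)c(Br)c1` keeps the core of compound 1 but has ethoxy in place of methyl on a carbonyl carbon, which turns acetyl into ethoxycarbonyl: ethoxy in place of methyl on a carbonyl carbon. For the measured compounds named here, the only measured step, a 3.9-fold higher number from compound 1 to compound 2 (0.59 log units; beyond the scatter), is modest and lies elsewhere, with naphthalen-1-yl in place of 2-chlorophenyl, so it offers only a rough sense of scale. No step beyond the scatter is therefore expected in this assay. The estimated change is a 1.2-fold higher number from compound 1 to compound 3 (0.07 log units; within the scatter). For compound 3 the expected value is 40000 nM, within a range of 14000 nM to 100000 nM.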

Compound 3, half-maximal cytotoxic concentration: 69000 nM
Beside the measured number, compound 3's estimate is 1.7-fold (0.24 log units) below it; measured number inside the range.
By their numbers in this assay, from the lowest: compound 1; then compounds 3 and 2 (each within the scatter of the next).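

Within this assay, ethoxy in place of methyl on a carbonyl carbon, which turns acetyl into ethoxycarbonyl, gives a 2.0-fold higher number from compound 1 to compound 3 (0.31 log units; beyond the scatter), a modest move toward lower toxicity in this test. So the number responds to the group on this carbonyl carbon as well, not only to the change of 2-chlorophenyl seen earlier. No measurement at hand explains this step. As far as these compounds go, it remains open whether the oxygen or the extra carbons of ethoxy matter here: a plain ethyl group or a carboxylic acid at this carbonyl carbon would help separate them. From the compounds shown here alone, whether the step holds with naphthalen-1-yl in place of 2-chlorophenyl also remains open.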